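A few compounds are considered here, and "the series" means these few. Any claim that something is new, unique, unknown or untested is made for them only; others in the source may bear on it.

Measured in a functional assay on MOLT-4 cells (Homo sapiens); a higher number here means a weaker inhibitor, a lower number a stronger inhibitor:
- Compound 1 `COc1cc(NC(C)CCCNC(=O)NCCO)c2ncccc2c1`: > 100000 nM, a limit
- Compound 2 `COc1cc(NC(C)CCCNC(=O)NOCc2ccccc2)c2ncccc2c1`: 12000 nM
- Compound 3 `COc1cc(NC(C)CCCNC(=O)NO)c2ncccc2c1`: > 100000 nM, a limit

From the compounds shown here alone, compound 3 gives only a limit, > 100000 nM, so its true standing is unknown. Compound 4 `CCOC(=O)NCCCC(C)Nc1cc(OC)cc2cccnc12` has ethoxy in place of hydroxyamino on a carbonyl carbon. Among the measured compounds shown here, no measured step makes this exact change. The nearest evidence comes from changes at the same end of the molecule. These are an at least 8.3-fold lower number from compound 1 to compound 2 (0.92 log units; beyond the scatter) and an at least 8.3-fold higher number from compound 2 to compound 3 (0.92 log units; beyond the scatter), both beyond the scatter and both bounded by a limit on one side. Only the benzyloxy group of compound 2, at 12000 nM, brought a measurable number. Ethoxy carries no ring, so only part of that gain is expected to carry over, and compound 4 may well stay at the limit. A modest move toward a lower number is therefore expected. The estimated step is an at least 2.0-fold lower number from compound 3 to compound 4 (0.30 log units; that floor lies within the scatter). For compound 4 the expected value is 50000 nM, with an estimated range from 15000 nM to 100000 nM.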

Compound 4, half-maximal inhibitory concentration: 34000 nM
Estimate against measurement, compound 4: 1.5-fold (0.17 log units) above; measured number inside the range.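

In this assay, compound 4 gives a second readable number at this carbonyl carbon, and its ethoxy carries no ring, so a ring at this end is not needed to come under the limit. The gain holds against both compounds that sit at the limit, with an at least 2.9-fold lower number from compound 3 to compound 4 (0.46 log units; beyond the scatter) and an at least 2.9-fold lower number from compound 1 to compound 4 (0.46 log units; beyond the scatter). The (benzyloxy)amino group still keeps its lead, with a 2.8-fold higher number from compound 2 to compound 4 (0.45 log units; beyond the scatter), so ethoxy matches only part of what that group gives.

From the compounds shown here alone, how far compound 1 and compound 3 truly lie from the others stays unknown, as each gives only a limit: the limit of > 100000 nM in this assay, at which 2 of the 4 values shown sit. Also open is whether a longer chain on the oxygen, such as butoxy or benzyloxy directly on the carbonyl carbon, would lower the number further.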